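Replacing the hydroxy of compound 3 with (diethylamino)methyl

This account rests on a few compounds, and the source may have more. Where it says the series, first, only, none or still open, it means among the compounds named here.

Measured in a functional assay on Raji cells (Homo sapiens) for antiproliferative activity, read by MTT assay, with a stated time of 48 h; a lower number here means a stronger inhibitor, a higher number a weaker inhibitor:
- compound 1 `Cn1c(N)c(-c2nc3ccccc3[nH]2)c2nc(C#N)c(C#N)nc21`: > 50000 nM (a limit)
- compound 2 `CCn1c(N)c(-c2nc3ccccc3[nH]2)c2nc(C#N)c(C#N)nc21`: > 50000 nM (a limit)
- compound 3 `N#Cc1nc2c(-c3nc4ccccc4[nH]3)c(N)n(CCO)c2nc1C#N`: 5520 nM

For the measured compounds named here, compound 3 holds the only true number in the set, 5520 nM. All that stands beside it is the limit of > 50000 nM in this assay, at which 2 of the 3 values shown sit.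

Compound 4 `CCN(CC)CCCn1c(N)c(-c2nc3ccccc3[nH]2)c2nc(C#N)c(C#N)nc21` carries (diethylamino)methyl in place of hydroxy on a saturated chain carbon, two bonds along the chain from an aromatic nitrogen.

The closest measured change is the arrival of that hydroxy, an at least 9.0-fold lower number from compound 2 to compound 3 (0.95 log units; beyond the scatter). Hydroxymethyl gave a similar result, an at least 9.0-fold lower number from compound 1 to compound 3 (0.95 log units; beyond the scatter). Methyl alone gave a step that the two limits leave unreadable from compound 1 to compound 2. Losing the hydroxy therefore points toward a weaker number, but no measured compound shows what (diethylamino)methyl does. In this assay no step beyond the scatter is expected, and that expectation is loose. The estimate means a 1.4-fold lower number from compound 3 to compound 4 (0.14 log units; within the scatter). Compound 4 is expected at 4000 nM, within an estimated range of 600 nM to 30000 nM.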

Compound 4, half-maximal inhibitory concentration: 1870 nM
For compound 4 the middle estimate is 2.1-fold (0.33 log units) above the measured one; the measured number falls inside the stated range.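

In this assay, the hydroxy of compound 3 proves not to be required for activity at this position: (diethylamino)methyl in its place gives a 3.0-fold lower number from compound 3 to compound 4 (0.47 log units; beyond the scatter), so the 3-(diethylamino)propyl chain outdoes the 2-hydroxyethyl chain. Against the two shorter chains, the same group gives an at least 26-fold lower number from compound 2 to compound 4 (1.42 log units; beyond the scatter) and an at least 26-fold lower number from compound 1 to compound 4 (1.42 log units; beyond the scatter). Both of these steps start from a limit and not from a true number, so they fix only a minimum size: the limit of > 50000 nM in this assay, at which 2 of the 4 values shown sit.

The compounds shown leave open whether the gain belongs to the diethylamino group or to the greater chain length, as compound 4 changes both at once. A propyl chain ending in hydroxy, or the same propyl chain ending in a primary amine or morpholine, would begin to separate the two.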